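The source may hold more compounds than are shown below. What is called first, only, known or untested is meant among the compounds shown, and "the series" means these compounds.

In an ADME assay on L02 cells (Homo sapiens) for cytotoxicity, read by MTT assay, with a stated time of 48 h (a lower number here means a stronger inhibitor, a higher number a weaker inhibitor), the measured compounds are:
Compound 1 `CCN(CC)CCNC(=O)c1ccc(C(CC)(CC)c2ccc(OCC(=O)C(C)(C)C)c(C)c2)n1CC` gives 2500 nM
Compound 2 `C#CCNC(=O)c1ccc(C(CC)(CC)c2ccc(OCC(O)C(C)(C)C)c(C)c2)n1CC` gives 4400 nM

Compound 2 and compound 1 lie within the usual scatter of each other, so neither ranks ahead. Compound 3 `CC[C@@H](C)[C@H](NC(=O)c1ccc(C(CC)(CC)c2ccc(OCC(O)C(C)(C)C)c(C)c2)n1CC)C(=O)O` carries 1-carboxy-2-methylbutyl in place of propargyl on an amide-type nitrogen. Within the data shown here, no measured pair differs in one place only, so the expectation rests on this structural change alone and stays uncertain. The expected change in this assay is a 2.0-fold higher number from compound 2 to compound 3 (0.31 log units; beyond the scatter), a modest move toward weaker inhibition near the edge of the scatter. For compound 3 the estimated value is 9000 nM (range 3500 nM to 25000 nM).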

Compound 3, half-maximal inhibitory concentration: 1400 nM
Compound 3: middle estimate off by 6.4-fold (0.81 log units), on the high side; measured number below the stated range.
By their numbers in this assay, from the lowest: compounds 3, 1 and 2 (each within the scatter of the next, the first and the last beyond it).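

In this assay, the amide-type nitrogen proves to be a position where the substituent matters: 1-carboxy-2-methylbutyl in place of propargyl gives a 3.1-fold lower number from compound 2 to compound 3 (0.50 log units; beyond the scatter). The step also shows that a larger substituent with 2 defined stereocentres is accommodated here without a rise in the number. Nothing available bears on the reason for this shift. Still open, going by these compounds, is whether the step follows the carboxylic acid or the branched chain, since both enter together. A carboxymethyl group or the methyl ester of the same acid on this nitrogen would separate the two.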